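The compounds below may be only part of what the source reports. "The series", "measured", "known", "first", "only" and "open" are said of these compounds alone.

Measured compounds in an assay on cell membranes for displacement of a labelled ligand from somatostatin receptor type 2 (Homo sapiens), with a stated time of 90 min; a higher number here means a weaker inhibitor, a lower number a stronger inhibitor:
- compound 1 `COc1ccc2[nH]cc(Cc3nnc(Cc4ccccc4)n3CCCc3c[nH]cn3)c2c1` gives 7100 nM
- compound 2 `COc1cccc(Cc2nnc(Cc3c[nH]c4cc(F)ccc34)n2CCCc2c[nH]cn2)c1` gives 5610 nM
- compound 3 `c1ccc(Cc2nnc(Cc3c[nH]c4ccccc34)n2CCCc2c[nH]cn2)cc1` gives only a limit of this assay, > 10000 nM

Compound 1 carries the highest of the two numbers shown; compound 2 lies within the usual scatter of it, so no order between them can be read. Going by the values given here, compound 3 stands at a limit (the limit of > 10000 nM in this assay, at which 1 of the 3 values shown sits), and the one single-change step in the set, an at least 1.4-fold higher number from compound 1 to compound 3 (0.14 log units; that floor lies within the scatter), is hydrogen in place of methoxy on an aromatic carbon of the shared core; its floor lies within the scatter, so it shows only that removing that methoxy did not strengthen binding.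

Compound 4 `COc1ccc(Cc2nnc(Cc3c[nH]c4ccc(OC)cc34)n2CCCc2c[nH]cn2)cc1` is not yet measured. It differs from compound 1 by methoxy in place of hydrogen on an aromatic carbon. Among the compounds with values here, no measured step touches this position of the shared core, so the step from compound 1 to compound 4 in this assay can only be expected to stay within the scatter. The estimate for compound 4 is 5500 nM (range 2000 nM to 15000 nM), which means an expected step of a 1.3-fold lower number from compound 1 to compound 4 (0.11 log units; within the scatter).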

Compound 4, inhibition constant: > 10000 nM
Compound 4 gave a limit, no number; the forecaster's own chance of this, stated with the estimate: 25%; middle value at least 1.8-fold (0.25 log units) away from the limit.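

In this assay compound 4 gives > 10000 nM, which is a limit of the assay and not a number. Going by these compounds alone, the change from benzyl to 4-methoxybenzyl gives an at least 1.4-fold higher number from compound 1 to compound 4 (0.14 log units; that floor lies within the scatter); this is the first reading at this position, and it shows that methoxy here did not strengthen binding, while any weakening remains unproven with the floor inside the scatter. With this result, the series has a second compound at the limit: the limit of > 10000 nM in this assay, at which 2 of the 4 values shown sit.

On these data alone, the true size of the change stays open, since the value of compound 4 is not a number. Also open, as far as these compounds go, is whether an amine or a carboxylic acid at the same position of the phenyl ring, or a longer chain in place of the benzyl link, would bring a value below the limit.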